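Swapping Phenyl for Thiophene on an Alkyne Arm

The compounds below may be only part of what the source reports. "The series", "measured", "known", "first", "only" and "open" are said of these compounds alone.

Going by the values given here, compound 2 `O=C1c2ccc(C#Cc3ccccc3)nc2CCN1C1CCCCC1` is the only compound here with a measured number: in a functional assay on HEK293 cells for positive allosteric modulation of metabotropic glutamate receptor 5 (Homo sapiens), read by FLIPR and calcium flux (on this read-out higher numbers stand for an effect only at larger amounts of compound and lower numbers for an effect already at smaller amounts), compound 2 gives 40 nM. Compound 1 `CC(C)N1CCc2nc(C#Cc3cccnc3)ccc2C1=O`, which carries a different group on the amide nitrogen and a pyridine on the alkyne, was recorded in this assay as "not active" (no number reported), so no number exists for it. Compound 3 `O=C1c2ccc(C#Cc3cccs3)nc2CCN1C1CCCCC1` differs from compound 2 by a single exchange: thiophen-2-yl in place of phenyl on a triple-bonded carbon. Among the compounds with values here, no measured step of this kind is available, so the expectation rests on the change being small; compound 3 is estimated to stay within the usual scatter, giving about 50 nM, between 15 nM and 160 nM, a step of a 1.3-fold higher number from compound 2 to compound 3 (0.10 log units; within the scatter).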

Compound 3, half-maximal effective concentration: 13 nM
For compound 3 the middle estimate is 3.8-fold (0.59 log units) above the measured one, outside the stated range (below it).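

Thiophen-2-yl in place of phenyl on a triple-bonded carbon gives a 3.1-fold lower number from compound 2 to compound 3 (0.49 log units; beyond the scatter) in this assay and shows that this ring can be exchanged with a measurable gain. Compound 1 could not show this, since it differs from compound 2 in more than one place. Nothing available explains the gain.

On these data alone, whether thiophen-3-yl or furan-2-yl would give a similar step remains open. So does whether the step would hold with a group other than cyclohexyl on the amide nitrogen.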